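A few compounds are considered here, and "the series" means these few. Any claim that something is new, unique, unknown or untested is made for them only; others in the source may bear on it.

Compound 1 `N/C(=N\NC(=S)N1CCOCC1)c1ccccn1`: 84.6%
Compound 2 `N/C(=N\NC(=S)N1CCN(c2ccccn2)CC1)c1ccc(F)cn1`: 77.1%
Compound 3 `Cc1ccnc(/C(N)=N/NC(=S)N2CCOCC2)c1`: 82.8%

These three compounds were measured in a functional assay on A-431 cells (Homo sapiens) for cytotoxicity, read by MTT assay, with a stated time of 72 h, tested at 100 uM; a lower number here means less inhibition of growth, a higher number more inhibition of growth at the concentration tested. Compound 1 gives 84.6%, which is the highest of the three numbers, though neither of the other two stands apart from it: the change from compound 1 to compound 3, methyl in place of hydrogen on an aromatic carbon, gives a number 1.8 percentage points lower from compound 1 to compound 3 (within the scatter), and compound 2, with 77.1%, lies within the scatter of compound 1 as well. Going by the values given here, nothing among the measured compounds therefore moves the read-out beyond its ordinary noise.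

Compound 4 `N/C(=N\NC(=S)N1CCSCC1)c1ccccn1` has not yet been measured in this assay. It differs from compound 1 in one place: thiomorpholin-4-yl in place of morpholin-4-yl on a thiocarbonyl carbon. Among the compounds with values here, no measured step bears directly on this exchange; the only single-point step available, from compound 1 to compound 3, concerns a different part of the molecule and was within the scatter, and the one larger change, seen in compound 2, also stayed within the scatter. On that basis the expected step from compound 1 to compound 4 is a number 1.6 percentage points lower from compound 1 to compound 4 (within the scatter), meaning no change beyond the scatter. Compound 4 is accordingly estimated at 83%, with a range from 70% to 92%.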

Compound 4, percent growth inhibition at one concentration: 80.8%
Compound 4: middle estimate off by 2.2 percentage points, on the high side; low and high end bracket the measured number.
By their numbers in this assay, from the lowest: compounds 2, 4, 3 and 1 (each within the scatter of the next).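

In this assay, going by these compounds alone, thiomorpholin-4-yl in place of morpholin-4-yl on a thiocarbonyl carbon gives a number 3.8 percentage points lower from compound 1 to compound 4 (within the scatter), the first measured step at this place in the molecule; the earlier single-point step, a number 1.8 percentage points lower from compound 1 to compound 3 (within the scatter), concerned an aromatic carbon instead. The exchange replaces the ring oxygen with sulfur while the ring size, the heavy-atom count and the counts of hydrogen-bond donors and acceptors stay the same, and a change of that limited kind does not move the growth-inhibition read-out beyond its usual scatter. No accompanying measurement bears on this result, so the data offer no explanation for it.

The compounds shown leave open whether a group departing further from these rings at the same thiocarbonyl carbon, such as piperidin-1-yl or an open-chain diethylamino group, would move the read-out beyond the scatter. They also leave open whether compound 1 and compound 4 would remain indistinguishable at other concentrations, since this comparison rests on growth inhibition at a single concentration, and a full concentration series could separate them or confirm their similarity.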